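The source may report more compounds than this note shows. Statements on the series, on what has been measured and on what is new or still open speak of the compounds shown alone.

The measured compounds in a functional assay on MDA-MB-231 cells (Homo sapiens) for cytotoxicity, read by MTT assay, with a stated time of 72 h; on this read-out lower numbers stand for stronger inhibition and higher numbers for weaker inhibition:
compound 1 `Cn1nc(-c2ccccc2)c2cc(C(=N)Nc3ccccc3)ncc21` gives 11100 nM
compound 2 `COc1cc(Nc2nc(C(=N)Nc3ccccc3)cc3c(-c4ccccc4)n[nH]c23)cc(OC)c1OC` gives 4500 nM
compound 3 `COc1ccc(Cn2cc3cc(C(=N)Nc4cccc(C(F)(F)F)c4)ncc3n2)cc1` gives 15500 nM

Among these three numbers compound 1 stands second highest. Its nearest neighbour is compound 3, whose value lies within the usual scatter of that of compound 1, so nothing can be said about an order between them. Compound 2 gives a number lower than compound 1 by a gap that lies beyond the scatter. Among the measured compounds shown here, no pair of these three differs in only one place, so no single step between measured compounds is available.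

The step now followed leads from compound 1 to compound 4 `COc1ccc(Cn2nc(-c3ccccc3)c3cc(C(=N)Nc4ccccc4)ncc32)cc1`, which has not yet been measured in this assay. The change is 4-methoxyphenyl in place of hydrogen on a saturated chain carbon bound to an aromatic nitrogen; read one bond further out, methyl becomes 4-methoxybenzyl. Compound 3 already carries a 4-methoxybenzyl on its core and, in this assay, compound 3 gives 15500 nM, a number close to that of compound 1. On that basis the step is expected to be small, with no direction beyond the scatter, and the estimate for the step is a 1.2-fold lower number from compound 1 to compound 4 (0.09 log units; within the scatter). Compound 4 is therefore expected to give about 9000 nM, with a likely range from 3000 nM to 30000 nM.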

Compound 4, half-maximal inhibitory concentration: 5400 nM
For compound 4 the middle estimate is 1.7-fold (0.22 log units) above the measured one, within the range that was stated.
By their numbers in this assay, from the lowest: compounds 2 and 4 (each within the scatter of the next); then compounds 1 and 3 (each within the scatter of the next).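

In this assay the step from methyl to 4-methoxybenzyl gives the first single change that can be read among these compounds, and it is a 2.1-fold lower number from compound 1 to compound 4 (0.31 log units; beyond the scatter). It shows that this place, on a saturated chain carbon bound to an aromatic nitrogen, takes a 4-methoxyphenyl of 8 heavy atoms in place of hydrogen without any weakening on this read-out, and that the number falls by a modest margin. Nothing available accounts for this step.

The compounds shown leave open whether the step belongs to the aromatic ring of the new group or to the methoxy group it carries, and a single step cannot show whether the trend would continue at this place. As far as these compounds go, how a plain benzyl, a longer alkyl chain, or a chain ending in an amine or a carboxylic acid would read at the same place also remains open.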